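Swapping the Aromatic Ring of Compound 1 for a Sulfur Group

The source may report more compounds than this note shows. Statements on the series, on what has been measured and on what is new or still open speak of the compounds shown alone.

Compound 1 `CN(C)C(=S)SC(=S)N1CCN(c2ccccc2)CC1` was tested in an ADME assay on HeLa cells (Homo sapiens) for cytotoxicity, read by MTT assay, with a stated time of 24 h (a higher number here means a weaker inhibitor, a lower number a stronger inhibitor), where compound 1 gives 1610000 nM. Compound 3 `CN(C)C(=S)SC(=S)N1CCN(c2cccc(Cl)c2Cl)CC1` gives 1590000 nM, which lies within the scatter of compound 1. Within the data shown here, compound 2 `COc1ccccc1N1CCN(C(=S)SC(=S)N(C)C)CC1` gives 4330000 nM; a 2.7-fold higher number from compound 1 to compound 2 (0.43 log units; beyond the scatter) is the only measured step, and it concerns a methoxy on the aromatic ring rather than the ring itself. Compound 4 `CSC(=S)N1CCN(C(=S)SC(=S)N(C)C)CC1` differs from compound 1 in a group of 4 heavy atoms (2 carbon, 2 sulfur; no ring) in place of a group of 6 heavy atoms (6 carbon; one six-membered aromatic ring of carbon only), on an amine nitrogen in a ring. Among the measured compounds shown here, no measured step removes the aromatic ring, so the evidence bears only indirectly on this change. Since even a 2.7-fold higher number from compound 1 to compound 2 (0.43 log units; beyond the scatter) was modest, the step from compound 1 to compound 4 is expected to be small, with no clear direction: an estimated 1.1-fold higher number from compound 1 to compound 4 (0.02 log units; within the scatter). Compound 4 is therefore expected to give about 1700000 nM, within a range from 500000 nM to 5500000 nM.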

Compound 4, half-maximal inhibitory concentration: > 5000000 nM
Compound 4: a limit, no number; the forecaster's own chance of this, stated with the estimate: 10%; middle value at least 2.9-fold (0.46 log units) from the limit.
By their numbers in this assay, from the lowest: compounds 3 and 1 (each within the scatter of the next); then compound 2. At a limit, above all of these: compound 4.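

The earlier compounds shown here changed only what sits on the aromatic ring, whereas compound 4 removes that ring from the amine nitrogen altogether. In this assay, putting the sulfur-bearing group in place of phenyl gives an at least 3.1-fold higher number from compound 1 to compound 4 (0.49 log units; beyond the scatter), so this position is not indifferent to the change. Compound 4 gives a limit, not a number: the limit of > 5000000 nM in this assay, at which 1 of the 4 values shown sits.

From the compounds shown here alone, the full size of the step therefore stays unknown. Going by these compounds, it also remains open whether losing the phenyl or adding the sulfur-bearing group drives the step, and how a cyclohexyl or benzyl group would behave here.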